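This account rests on a few compounds, and the source may have more. Where it says the series, first, only, none or still open, it means among the compounds named here.

In a functional assay on HepG2 cells (Homo sapiens) for inhibition, read by MTT assay, with a stated time of 24 h (on this read-out lower numbers stand for stronger inhibition of growth and higher numbers for weaker inhibition of growth), compound 1 `COc1ccc2c(c1)c(-c1nc3ccccc3n1C(=O)c1ccccc1OC)cn2C` gives 23600 nM, compound 2 `COc1cccc(C(=O)n2c(-c3cn(C)c4ccc(OC)cc34)nc3ccccc32)c1` gives 11700 nM and compound 3 `COc1ccc2c(c1)c(-c1nc3ccccc3n1C(=O)c1ccccc1Br)cn2C` gives 54200 nM. Compound 1 stands amid these numbers: the nearest is a 2.0-fold lower number from compound 1 to compound 2 (0.30 log units; within the scatter), and the furthest is a 2.3-fold higher number from compound 1 to compound 3 (0.36 log units; beyond the scatter). Compound 4 `COc1ccccc1C(=O)n1c(-c2cn(C)c3ccc(Br)cc23)nc2ccccc21` changes the core of compound 1 as follows: bromo in place of methoxy on an aromatic carbon. This is bromo in place of methoxy on an aromatic carbon of a six-membered aromatic ring of carbon only, part of a fused or bridged system of two rings. Within the data shown here, the only precedent for this exchange is compound 3, at a 2.3-fold higher number from compound 1 to compound 3 (0.36 log units; beyond the scatter), but there it replaces the methoxy of the 2-methoxyphenyl group, so it transfers loosely. Among the measured compounds shown here, a modest rise in this assay is therefore expected, with no measured step covering this position. The estimated step is a 1.5-fold higher number from compound 1 to compound 4 (0.17 log units; within the scatter). For compound 4 the estimated value is 35000 nM, with an expected range of 13000 nM to 90000 nM.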

Compound 4, concentration for 50% growth inhibition: 34600 nM
The estimate for compound 4 lay 1.0-fold (0.00 log units) above the measured number, within the range that was stated.
By their numbers in this assay, from the lowest: compounds 2, 1, 4 and 3 (each within the scatter of the next, the first and the last beyond it).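

On the core of compound 1, bromo in place of methoxy gives a 1.5-fold higher number from compound 1 to compound 4 (0.17 log units; within the scatter) in this assay and so leaves the number within the scatter at this position. The same exchange on the 2-methoxyphenyl group gives a 2.3-fold higher number from compound 1 to compound 3 (0.36 log units; beyond the scatter) and therefore does not describe this position. No measurement on hand accounts for this result. Open, from the compounds shown here alone, is whether an amine or a carboxylic acid at this position would shift the number, and whether bromo here combines with 3-methoxyphenyl on the carbonyl carbon.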